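Swapping the Ester of Compound 3 for a Methoxime

The source may hold more compounds than are shown below. What is called first, only, known or untested is meant among the compounds shown, and "the series" means these compounds.

Compound 3 `COC(=O)c1ccc(CN(Cc2nc3ccccc3[nH]2)C2CCCc3cccnc32)c(CN)c1` gives 39 nM in a functional assay on CEM-CCRF cells for antagonist activity at C-X-C chemokine receptor type 4 (Homo sapiens), read by calcium flux; on this read-out higher numbers stand for weaker inhibition and lower numbers for stronger inhibition. Among the three measured compounds it stands second highest: compound 1 `NCc1ccccc1CN(Cc1nc2ccccc2[nH]1)C1CCCc2cccnc21` gives 28 nM, and a 1.4-fold higher number from compound 1 to compound 3 (0.14 log units; within the scatter) lies within the scatter, whereas compound 2 `NCc1cc(C(=O)O)ccc1CN(Cc1nc2ccccc2[nH]1)C1CCCc2cccnc21` gives 126 nM and a 3.2-fold lower number from compound 2 to compound 3 (0.51 log units; beyond the scatter) lies beyond it. Compound 4 `CO/N=C/c1ccc(CN(Cc2nc3ccccc3[nH]2)C2CCCc3cccnc32)c(CN)c1` carries a group of 4 heavy atoms (2 carbon, 1 nitrogen, 1 oxygen; no ring) in place of a group of 4 heavy atoms (2 carbon, 2 oxygen; no ring), on an aromatic carbon. For the measured compounds named here, no measured step swaps these two groups directly. The nearest guides are a 1.4-fold higher number from compound 1 to compound 3 (0.14 log units; within the scatter), where adding a methoxycarbonyl changed little, and a 3.2-fold lower number from compound 2 to compound 3 (0.51 log units; beyond the scatter), where the carboxy group gave the higher number. The entering group, like the methoxycarbonyl, is counted with no hydrogen-bond donor and no charge. Compound 4 is therefore expected to show a 1.2-fold higher number from compound 3 to compound 4 (0.06 log units; within the scatter), a step within the scatter. The estimate for compound 4 is 45 nM, ranging from 15 nM to 130 nM.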

Compound 4, half-maximal inhibitory concentration: 5 nM
Compound 4: the middle estimate sits 9.0-fold (0.95 log units) above what was measured; measured number below the stated range.
By their numbers in this assay, from the lowest: compound 4; then compounds 1 and 3 (each within the scatter of the next); then compound 2.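

At this position, no earlier group had given a lower number than hydrogen in this assay, but the methoxime does, with a 5.6-fold lower number from compound 1 to compound 4 (0.75 log units; beyond the scatter) for the change. It also improves on the methoxycarbonyl with a 7.8-fold lower number from compound 3 to compound 4 (0.89 log units; beyond the scatter) even though both groups have the same counts of heavy atoms, hydrogen-bond donors and acceptors, and the largest gap is to the carboxy group with a 25-fold lower number from compound 2 to compound 4 (1.40 log units; beyond the scatter) in this series. Nothing measured here explains these gains. The compounds shown leave open whether an ethyl oxime, with its longer chain, or a primary amide on this aromatic carbon would keep the number as low.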